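Heteroaryl exchange on the ring amine nitrogen of compound 1

The source may report more compounds than this note shows. Statements on the series, on what has been measured and on what is new or still open speak of the compounds shown alone.

Compound 1 `Nc1scc(CN2CCN(c3ccccc3)CC2)c1C(=O)c1ccc(Cl)cc1` is measured in an assay on CHO cells for displacement of a labelled ligand from adenosine receptor A1 (Homo sapiens) (on this read-out higher numbers stand for weaker binding and lower numbers for tighter binding), at 1 nM. Compound 2 `Nc1scc(CN2CCN(c3ccc(F)cc3)CC2)c1C(=O)c1ccc(Cl)cc1` gives 1 nM and compound 3 `Nc1scc(CN2CCN(c3ccccn3)CC2)c1C(=O)c1ccc(Cl)cc1` gives 1.2 nM. Compound 1 stands level with compound 2 at the digits shown, the two together the lowest of the three numbers, and both no change at the digits printed from compound 1 to compound 2 (within the scatter) and a 1.2-fold higher number from compound 1 to compound 3 (0.08 log units; within the scatter) stay within the scatter. Compound 4 `Nc1scc(CN2CCN(c3ncccn3)CC2)c1C(=O)c1ccc(Cl)cc1` is not yet measured; its change from compound 1 is pyrimidin-2-yl in place of phenyl on an amine nitrogen in a ring. Among the measured compounds shown here, the step that bears on this is the one from compound 1 to compound 3, an aromatic nitrogen entering at the same site, and a 1.2-fold higher number from compound 2 to compound 3 (0.08 log units; within the scatter) agrees with it. Expected for compound 4 is therefore a 1.5-fold higher number from compound 1 to compound 4 (0.18 log units; within the scatter), no step beyond the scatter. The estimate for compound 4 in this assay is 1.5 nM, range 0.6 nM to 4 nM.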

Compound 4, dissociation constant: 1.1 nM
Compound 4: middle estimate off by 1.4-fold (0.13 log units), on the high side; the range from low to high includes it.
By their numbers in this assay, from the lowest: compounds 1, 2, 4 and 3 (each within the scatter of the next).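

In this assay, pyrimidin-2-yl on the amine nitrogen in a ring gives a 1.1-fold higher number from compound 1 to compound 4 (0.04 log units; within the scatter) and a 1.1-fold higher number from compound 2 to compound 4 (0.04 log units; within the scatter) and a 1.1-fold lower number from compound 3 to compound 4 (0.04 log units; within the scatter) as its steps. The earlier compounds shown here carried no more than one ring nitrogen in this group, so this result extends the flat picture to a ring with two hetero atoms and two hydrogen-bond acceptors. Nothing available explains this flat picture.

From the compounds shown here alone, whether any group at this site moves the number beyond the scatter stays open. A benzyl or acetyl group on that nitrogen, or a carboxylic acid on the aromatic ring, would test this.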